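Terminal hydroxyl kept, two ether oxygens dropped: compound 4

The source may report more compounds than this note shows. Statements on the series, on what has been measured and on what is new or still open speak of the compounds shown alone.

The series shares one core; compound 1 `O=c1c(-c2ccc(O)cc2)coc2cc(OCCOCCOCCO)ccc12` carries 2-(2-hydroxyethoxy)ethoxy on a saturated chain carbon, two bonds along the chain from an oxygen on an aromatic ring. In an assay (Cricetulus griseus) for inhibition of aldehyde dehydrogenase, mitochondrial (Homo sapiens) (a lower number here means a stronger inhibitor, a higher number a weaker inhibitor), compound 1 gives 40 nM, level with compound 3 `O=C(O)CCCCCCCOc1ccc2c(=O)c(-c3ccc(O)cc3)coc2c1` at 40 nM and together the lowest of the three numbers, while compound 2 `CCCCCCOc1ccc2c(=O)c(-c3ccc(O)cc3)coc2c1` lies furthest off at 1500 nM. Compound 4 `O=c1c(-c2ccc(O)cc2)coc2cc(OCCCCCCO)ccc12` differs from compound 1 by 4-hydroxybutyl in place of 2-(2-hydroxyethoxy)ethoxy on a saturated chain carbon, two bonds along the chain from an oxygen on an aromatic ring. Both measured steps out of compound 1 bear on this change: a 38-fold higher number from compound 1 to compound 2 (1.57 log units; beyond the scatter) when a butyl end stood in place of the hydroxyl-bearing chain, and no change at the digits printed from compound 1 to compound 3 (within the scatter) when a 5-carboxypentyl end did. Compound 4 keeps a hydroxyl at the end of the chain yet loses the two ether oxygens, so it is expected to land between those two outcomes, with a moderate rise in the number, a 3.8-fold higher number from compound 1 to compound 4 (0.57 log units; beyond the scatter). Compound 4 is therefore estimated at 150 nM, within a range of 40 nM to 600 nM.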

Compound 4, half-maximal inhibitory concentration: 120 nM
Compound 4: the middle estimate sits 1.3-fold (0.10 log units) above what was measured; the measured number falls inside the stated range.
By their numbers in this assay, from the lowest: compounds 1 and 3 (each within the scatter of the next); then compound 4; then compound 2.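

In this assay, hydroxy in place of hydrogen at the chain end gives a 13-fold lower number from compound 2 to compound 4 (1.10 log units; beyond the scatter), so a terminal hydroxyl on an all-carbon chain already recovers much of the difference between compound 2 and compound 1. That recovery is incomplete: 4-hydroxybutyl in place of 2-(2-hydroxyethoxy)ethoxy gives a 3.0-fold higher number from compound 1 to compound 4 (0.48 log units; beyond the scatter), and hydroxy in place of carboxymethyl gives a 3.0-fold higher number from compound 3 to compound 4 (0.48 log units; beyond the scatter), so the same terminal hydroxyl is not interchangeable with either the ether-containing chain or the carboxylic acid end. No measurement at hand gives a reason for these differences.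

Still open, as far as these compounds go, is whether an amine or a primary amide at the chain end would track compound 4 or compound 3. Also open, from the compounds shown here alone, is whether a longer chain ending in hydroxyl would close the remaining difference from compound 1.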